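Amide aryl variation on the shared core: towards compound 4

A few compounds are considered here, and "the series" means these few. Any claim that something is new, unique, unknown or untested is made for them only; others in the source may bear on it.

Compounds 1, 2 and 3 share one core and differ only in the aryl group on the amide carbonyl. Compound 1 `Cc1ccccc1C(=O)Nc1cccc(-c2oc3cc(-c4ccc(F)cc4)ccc3c(=O)c2O)c1` carries a 2-methylphenyl there, and in a functional assay on MCF7 cells (Homo sapiens) for antiproliferative activity, read by CCK-8 assay, with a stated time of 72 h (a lower number here means a stronger inhibitor, a higher number a weaker inhibitor), compound 1 gives 2280 nM. Compound 2 `O=C(Nc1cccc(-c2oc3cc(-c4ccc(F)cc4)ccc3c(=O)c2O)c1)c1ccc(Br)cc1` carries a 4-bromophenyl and gives 24000 nM. Compound 3 `O=C(Nc1cccc(-c2oc3cc(-c4ccc(F)cc4)ccc3c(=O)c2O)c1)c1cccc(F)c1` carries a 3-fluorophenyl and gives 5770 nM; compound 3 thus stands second highest of the three numbers, with compound 1 nearest and compound 2 furthest. The steps between them are a 2.5-fold higher number from compound 1 to compound 3 (0.40 log units; beyond the scatter), an 11-fold higher number from compound 1 to compound 2 (1.02 log units; beyond the scatter) and a 4.2-fold lower number from compound 2 to compound 3 (0.62 log units; beyond the scatter).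

Compound 4 `O=C(Nc1cccc(-c2oc3cc(-c4ccc(F)cc4)ccc3c(=O)c2O)c1)c1ccc(-c2ccccc2)cc1` follows from compound 3 by one change: 4-phenylphenyl in place of 3-fluorophenyl on a carbonyl carbon. Within the data shown here, the steps that bear on it are the two involving the 4-bromophenyl group, an 11-fold higher number from compound 1 to compound 2 (1.02 log units; beyond the scatter) and a 4.2-fold lower number from compound 2 to compound 3 (0.62 log units; beyond the scatter): a group substituted in that way gave the highest number in the set, and compound 4 carries a whole second six-membered aromatic ring at that same place. A step upward beyond the scatter is therefore expected, of about a 4.3-fold higher number from compound 3 to compound 4 (0.64 log units; beyond the scatter), bringing compound 4 near or beyond compound 2 with its 24000 nM. Compound 4 is expected to give 25000 nM, within a range from 8000 nM to 80000 nM, with some chance that only a limit is reported.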

Compound 4, half-maximal inhibitory concentration: 38500 nM
Compound 4: the middle estimate sits 1.5-fold (0.19 log units) below what was measured, and the stated range covers the measured number.
By their numbers in this assay, from the lowest: compound 1; then compound 3; then compounds 2 and 4 (each within the scatter of the next).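

In this assay, phenyl in place of bromo on an aromatic carbon leaves the number within the scatter (a 1.6-fold higher number from compound 2 to compound 4 (0.21 log units; within the scatter)), so compound 2 and compound 4 cannot be told apart, although the 4-phenylphenyl group brings a second six-membered aromatic ring of carbon only. The 4-phenylphenyl group on the carbonyl carbon also stays clearly apart from the two other aryl groups (a 6.7-fold higher number from compound 3 to compound 4 (0.82 log units; beyond the scatter); a 17-fold higher number from compound 1 to compound 4 (1.23 log units; beyond the scatter)), so among these four compounds the 4-bromophenyl and 4-phenylphenyl groups share the high end, while the 3-fluorophenyl and 2-methylphenyl groups give lower numbers. Nothing available explains these differences.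

Each substituent in the set differs from the others in both its identity and its place on the ring, so the effect of the substituent cannot be separated from the effect of where it stands. On these data alone, it also remains open how an aryl group bearing an amine or a carboxylic acid, or an unsubstituted phenyl on the same carbonyl carbon, would compare with the 2-methylphenyl group of compound 1.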